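Swapping Chloro for Bromo on Compound 2

The compounds below may be only part of what the source reports. "The series", "measured", "known", "first", "only" and "open" are said of these compounds alone.

Of the compounds shown here, two have so far been measured in an assay for binding affinity to protein lin-28 homolog A (Mus musculus), with a stated time of 1 h; on this read-out lower numbers stand for stronger inhibition and higher numbers for weaker inhibition. Compound 1 `O=S(=O)(Nc1ccccc1NS(=O)(=O)c1ccc(F)cc1)c1ccc(F)cc1` gives 28300 nM in this assay, while compound 2 `O=S(=O)(Nc1ccccc1NS(=O)(=O)c1cccc(Cl)c1)c1ccc(F)cc1` gives 10800 nM, the lowest of the two numbers, and the step of a 2.6-fold lower number from compound 1 to compound 2 (0.42 log units; beyond the scatter) lies beyond the scatter. Compound 3 `O=S(=O)(Nc1ccccc1NS(=O)(=O)c1cccc(Br)c1)c1ccc(F)cc1` has not yet been measured; it differs from compound 2 in one place, (bromo in place of chloro on an aromatic carbon), that is, bromo in place of chloro on an aromatic carbon. Among the measured compounds shown here, the only measured step, a 2.6-fold lower number from compound 1 to compound 2 (0.42 log units; beyond the scatter), exchanged a whole substituted ring rather than one halogen for another, so it bears on this change only loosely. For the measured compounds named here, no measured pair shows a halogen-for-halogen swap, and in the present change one heavy atom leaves and one enters. In this assay compound 3 is therefore expected to give about 9000 nM, with a range from 3500 nM to 25000 nM. The estimated step of a 1.2-fold lower number from compound 2 to compound 3 (0.08 log units; within the scatter) is expected to stay within the scatter.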

Compound 3, half-maximal inhibitory concentration: 16200 nM
Compound 3: the middle estimate sits 1.8-fold (0.26 log units) below what was measured; low and high end bracket the measured number.
By their numbers in this assay, from the lowest: compounds 2, 3 and 1 (each within the scatter of the next, the first and the last beyond it).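

Among the compounds shown here, the halogen swap gives the first direct reading at this place on the ring: a 1.5-fold higher number from compound 2 to compound 3 (0.18 log units; within the scatter) in this assay, so bromo and chloro cannot be told apart here. The comparison with the starting compound adds a caution, since a 1.7-fold lower number from compound 1 to compound 3 (0.24 log units; within the scatter) stays within the scatter, whereas the step from compound 1 to compound 2 lies beyond it; the gain seen with 3-chlorophenyl therefore does not clearly carry over to 3-bromophenyl. No accompanying measurement bears on why these numbers fall as they do.

The compounds shown leave open how an amine, a carboxylic acid or a methoxy group would read at this same place on the ring. They also leave open whether a non-halogen group here could move the number clearly beyond the scatter of compound 2.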